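Halogen pattern swap on the benzylidene arm

The source may hold more compounds than are shown below. What is called first, only, known or untested is meant among the compounds shown, and "the series" means these compounds.

Compound 2 `C=CCn1c(=O)/c(=C\c2cccc(Cl)c2Cl)[nH]c(=O)/c1=C\c1ccccc1OC` gives the lowest of the two numbers measured in a functional assay on MCF7 cells (Homo sapiens) for cytotoxicity, read by CCK-8 assay, with a stated time of 72 h (on this read-out lower numbers stand for stronger inhibition and higher numbers for weaker inhibition), where compound 2 gives 2100 nM; its nearest neighbour, compound 1 `C=CCn1c(=O)/c(=C\c2ccccc2Cl)[nH]c(=O)/c1=C\c1ccccc1OC`, gives 4700 nM. Compound 3 `C=CCn1c(=O)/c(=C\c2cc(Br)ccc2F)[nH]c(=O)/c1=C\c1ccccc1OC` carries 5-bromo-2-fluorophenyl in place of 2,3-dichlorophenyl on a double-bonded chain carbon bound to an aromatic carbon. Among the measured compounds shown here, the only measured step, a 2.2-fold lower number from compound 1 to compound 2 (0.35 log units; beyond the scatter), concerns a single added chloro on that ring and bears on this change only loosely, since here two halogens are exchanged rather than added. Compound 3 is therefore expected to stay within roughly the same range, with a small step of a 1.4-fold higher number from compound 2 to compound 3 (0.15 log units; within the scatter), giving an estimate of 3000 nM between 1200 nM and 7500 nM.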

Compound 3, half-maximal inhibitory concentration: 28100 nM
Compound 3: middle estimate off by 9.4-fold (0.97 log units), on the low side; the whole stated range lies below it.
By their numbers in this assay, from the lowest: compound 2; then compound 1; then compound 3.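

Exchanging halogens at this position is far from neutral: although both groups have the same heavy-atom count, 5-bromo-2-fluorophenyl in place of 2,3-dichlorophenyl gives a 13-fold higher number from compound 2 to compound 3 (1.13 log units; beyond the scatter) in this assay. The same group also compares poorly with the singly substituted 2-chlorophenyl, giving a 6.0-fold higher number from compound 1 to compound 3 (0.78 log units; beyond the scatter), so compound 3 has the highest number of the three. Nothing shown here accounts for this loss. Which of the two halogens in 5-bromo-2-fluorophenyl carries the change stays open, as does how an amine or a nitrile on this ring would compare.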